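The source may report more compounds than this note shows. Statements on the series, on what has been measured and on what is new or still open speak of the compounds shown alone.

Among the compounds with values here, compound 1 `COc1ccc(Cn2c(CCc3ccccc3)nnc2[C@H](NC(=O)c2ccncc2)c2c[nH]c3ccccc23)c(OC)c1` is the only member of this set with a number: in a functional assay on CHO cells for antagonist activity at growth hormone secretagogue receptor type 1 (Homo sapiens) (on this read-out higher numbers stand for weaker inhibition and lower numbers for stronger inhibition), compound 1 gives 93 nM. Compound 2 `CCc1ccc(Cn2c(CCc3ccccc3)nnc2[C@H](NC(=O)c2ccncc2)c2c[nH]c3ccccc23)cc1` shares the same core, and in this assay compound 2 gives "not determined" (no result reported), so no single number places it among the others. Compound 3 `COc1ccc(Cn2c(CCc3ccccc3)nnc2[C@H](NC(=O)c2ccncc2)c2c[nH]c3ccccc23)cc1` likewise gives "not determined" (no result reported) in this assay. Compound 4 `CCc1ccc(Cn2c(CCc3ccccc3)nnc2[C@H](NC(=O)Cc2ccccn2)c2c[nH]c3ccccc23)cc1` differs from compound 2 by (pyridin-2-yl)methyl in place of pyridin-4-yl on a carbonyl carbon. Within the data shown here, no measured pair shows what this change does. With nothing to anchor compound 2, the expectation for the step in this assay is loose: a shift toward weaker inhibition of modest size, possibly within the scatter. Compound 4 is therefore estimated at 250 nM in this assay, within a wide range from 40 nM to 1500 nM.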

Compound 4, antagonist equilibrium constant: 124 nM
For compound 4 the middle estimate is 2.0-fold (0.30 log units) above the measured one; low and high end bracket the measured number.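

Compound 2 has no single number, so the step to compound 4 cannot be read. From the compounds shown here alone, what replacing pyridin-4-yl with (pyridin-2-yl)methyl does to inhibition stays open. Nothing shown here bears on this result.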